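The source may report more compounds than this note shows. Statements on the series, on what has been measured and on what is new or still open speak of the compounds shown alone.

Measured so far:
Compound 1, `S=C(Nc1ccccc1)Nc1ccc2[nH]ccc2c1`: 337000 nM
Compound 2, `Oc1ccc(NC(=S)Nc2ccc3[nH]ccc3c2)cc1`: 848000 nM

In an ADME assay on CHO-K1 cells (Cricetulus griseus) for cytotoxicity, read by MTT assay, with a stated time of 24 h (a higher number here means that more compound is tolerated, a lower number that less compound is tolerated), compound 2 gives the higher of the two numbers, 848000 nM, and its nearest neighbour, compound 1, gives 337000 nM. Going by the values given here, the single measured step, a 2.5-fold higher number from compound 1 to compound 2 (0.40 log units; beyond the scatter), is a modest rise that lies beyond the scatter.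

Compound 3, `CCOC(=O)c1ccc(NC(=S)Nc2ccc3[nH]ccc3c2)cc1`, is reached from compound 2 by ethoxycarbonyl in place of hydroxy on an aromatic carbon. Among the compounds with values here, only one measured step bears on this change, and only in part: it shows what adding a hydroxy did, so taking the hydroxy away again would, on that evidence alone, point back toward the number of compound 1. Nothing measured here tells what an ethoxycarbonyl does at this place, so the second half of the change is an open question. On balance a small fall or no step beyond the scatter is expected, with a 1.9-fold lower number from compound 2 to compound 3 (0.28 log units; within the scatter) as the expected step for compound 3. The estimate for compound 3 is therefore 450000 nM, with a range from 170000 nM to 1100000 nM.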

Compound 3, concentration lethal to 50% of the cells: 123000 nM
The estimate for compound 3 lay 3.7-fold (0.56 log units) above the measured number; the whole stated range lies above it.
By their numbers in this assay, from the lowest: compound 3; then compound 1; then compound 2.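

In this assay, a group at this place on the aromatic ring can move the number down as well as up: ethoxycarbonyl in place of hydrogen gives a 2.7-fold lower number from compound 1 to compound 3 (0.44 log units; beyond the scatter), the opposite direction to the rise seen with hydroxy. Exchanging one group for the other gives a 6.9-fold lower number from compound 2 to compound 3 (0.84 log units; beyond the scatter), a step larger than either step from the hydrogen-bearing compound, so the two groups lie on opposite sides of it and the result depends on which group is present, not merely on whether the position is filled. No measurement at hand explains why these two groups act in opposite directions.

On these data alone, with only hydrogen, hydroxy and ethoxycarbonyl to compare, it remains open whether the fall belongs to the whole ethoxycarbonyl group or would also appear with a carboxylic acid, a methoxycarbonyl or a longer ester chain. As far as these compounds go, it also remains open on which side of compound 1 an amine at this place would fall, and whether hydroxy and ethoxycarbonyl would give the same order elsewhere on the ring.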